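The source may report more compounds than this note shows. Statements on the series, on what has been measured and on what is new or still open speak of the compounds shown alone.

Of the compounds shown here, three sharing one macrocyclic core have been measured in a functional assay on MCF7 cells (Homo sapiens) for antiproliferative activity, read by MTT assay, with a stated time of 48 h; on this read-out higher numbers stand for weaker inhibition and lower numbers for stronger inhibition. Compound 1 `CO[C@]1(C)/C=C/C(=O)/C(CO)=C\C[C@](C)(CCC=C(C)C)/C=C/[C@H]1OC(=O)C=C(C)C` gives 14300 nM, compound 3 `CC(C)=CCC[C@]1(C)/C=C/[C@@H](OC(=O)C=C(C)C)[C@](C)(O)/C=C/C(O)/C(C=O)=C\C1` gives 2320 nM, and compound 2 `CC(C)=CCC[C@]1(C)/C=C/[C@@H](OC(=O)C=C(C)C)[C@](C)(O)/C=C/C(=O)/C(CN(C(C)C)C(C)C)=C\C1` gives 780 nM, the lowest of the three numbers; its gaps to compound 3 and to compound 1 both lie beyond the usual scatter, so compound 2 is the strongest inhibitor of the set. Compound 4 `CO/N=C/C1=C/C[C@](C)(CCC=C(C)C)/C=C/[C@@H](OC(=O)C=C(C)C)[C@](C)(O)/C=C/C1=O` has not yet been measured. It differs from compound 2 in one place: a group of 4 heavy atoms (2 carbon, 1 nitrogen, 1 oxygen; no ring) in place of a group of 8 heavy atoms (7 carbon, 1 nitrogen; no ring), on a double-bonded ring carbon. Among the compounds with values here, no measured pair differs only at this spot, so the step has no direct precedent; a moderate weakening beyond the scatter is expected. Compound 4 is expected to give 2000 nM in this assay, with a likely range from 600 nM to 7000 nM. This expected step is a 2.6-fold higher number from compound 2 to compound 4 (0.41 log units; beyond the scatter).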

Compound 4, half-maximal inhibitory concentration: 2510 nM
For compound 4 the middle estimate is 1.3-fold (0.10 log units) below the measured one; the range from low to high includes it.
By their numbers in this assay, from the lowest: compound 2; then compounds 3 and 4 (each within the scatter of the next); then compound 1.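

In this assay, within the data shown here, replacing the (diisopropylamino)methyl group on this double-bonded ring carbon with the group of 4 heavy atoms in compound 4 gives a 3.2-fold higher number from compound 2 to compound 4 (0.51 log units; beyond the scatter), the first direct reading of a change at this position. The step is modest, and compound 4 still has a measurable value, so this carbon accepts a smaller group without the amine, at some cost. On these data alone, whether a smaller amine, such as dimethylaminomethyl, would keep the number of compound 2 remains open. Nothing shown here explains why the number rises.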